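The compounds below may be only part of what the source reports. "The series", "measured", "known", "first", "only" and "open" are said of these compounds alone.

Within the data shown here, compound 3 `COc1cc2c(Oc3ccc(NC(=O)c4cn(-c5ccccc5C)nn4)cc3F)ccnc2cc1OCCCN1CCCCC1` gives 1340 nM in a functional assay on HT-29 cells (Homo sapiens) for cytotoxicity, read by MTT assay, with a stated time of 72 h (a lower number here means a stronger inhibitor, a higher number a weaker inhibitor), the highest of the three numbers measured so far. Compound 1 `COc1cc2c(Oc3ccc(NC(=O)c4cn(-c5ccccc5C)nn4)cc3F)ccnc2cc1OCCCN1CCCC1` gives 1200 nM in this assay, and compound 2 `COc1cc2c(Oc3ccc(NC(=O)c4cn(-c5ccccc5)nn4)cc3F)ccnc2cc1OCCCN1CCCCC1` gives 180 nM in this assay. Two single changes lead into compound 3. a 1.1-fold higher number from compound 1 to compound 3 (0.05 log units; within the scatter), so that exchange leaves the number essentially where it was. a 7.4-fold higher number from compound 2 to compound 3 (0.87 log units; beyond the scatter), so the group on that aromatic carbon clearly matters to the read-out.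

Compound 4 `COc1cc2c(Oc3ccc(NC(=O)c4cn(-c5ccccc5F)nn4)cc3F)ccnc2cc1OCCCN1CCCCC1` differs from compound 3 by fluoro in place of methyl on an aromatic carbon. Among the measured compounds shown here, only the step from compound 2 to compound 3 bears on this change, and it shows the smaller group, hydrogen, going with the lower number. For the measured compounds named here, no measured compound shows what fluoro does at this place, so the step can only be expected to fall somewhere between the numbers of compound 2 and compound 3. The expected step is a 3.0-fold lower number from compound 3 to compound 4 (0.47 log units; beyond the scatter). Compound 4 is therefore estimated at 450 nM, with a range from 150 nM to 1400 nM.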

Compound 4, half-maximal inhibitory concentration: 290 nM
The estimate for compound 4 lay 1.6-fold (0.19 log units) above the measured number; low and high end bracket the measured number.
By their numbers in this assay, from the lowest: compounds 2 and 4 (each within the scatter of the next); then compounds 1 and 3 (each within the scatter of the next).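

In this assay, fluoro in place of methyl gives a 4.6-fold lower number from compound 3 to compound 4 (0.66 log units; beyond the scatter), so the higher number seen with methyl does not extend to every single-atom replacement of hydrogen at this place. Fluoro in place of hydrogen gives a 1.6-fold higher number from compound 2 to compound 4 (0.21 log units; within the scatter), which leaves those two groups indistinguishable here and makes methyl the only one of the three with a clearly higher number. Methyl and fluoro each count as one heavy atom, and nothing measured here accounts for the difference between them.

From the compounds shown here alone, it remains open whether chloro, methoxy or ethyl on this aromatic carbon would fall with fluoro and hydrogen or with methyl. Going by these compounds, it is also open whether fluoro would give the same result with pyrrolidin-1-yl in place of piperidin-1-yl at the end of the chain.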